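The source may hold more compounds than are shown below. What is called first, only, known or untested is meant among the compounds shown, and "the series" means these compounds.

Compound 1 `O=C(Nc1ccc(Oc2ccnc3[nH]ccc23)cc1)c1nccc(-c2cccc(Cl)c2)n1`: 7800 nM
Compound 2 `O=C(Nc1ccc(Oc2ccnc3[nH]ccc23)c(F)c1)c1nccc(-c2cccc(Cl)c2)n1`: 1380 nM

In a functional assay on PC-3 cells (Homo sapiens) for cytotoxicity, read by MTT assay, with a stated time of 72 h (a lower number here means a stronger inhibitor, a higher number a weaker inhibitor), compound 2 stands lowest of the two numbers measured; its nearest neighbour is compound 1, separated by a 5.7-fold lower number from compound 1 to compound 2 (0.75 log units; beyond the scatter). Compound 3 `O=C(Nc1ccc(Oc2ccnc3[nH]ccc23)c(F)c1)c1nccc(-c2ccc(Cl)cc2)n1` differs from compound 2 by 4-chlorophenyl in place of 3-chlorophenyl on an aromatic carbon. Going by the values given here, no measured step touches the chlorophenyl group: the only step measured, between compound 1 and compound 2, changed the fluoro alone, so the data give no guide to the size or direction of this change. Compound 3 is expected to show a 1.0-fold higher number from compound 2 to compound 3 (0.01 log units; within the scatter), no step beyond the scatter. The estimate for compound 3 in this assay is 1400 nM, within 450 nM to 4500 nM.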

Compound 3, half-maximal inhibitory concentration: 14600 nM
Estimate against measurement, compound 3: 10-fold (1.02 log units) below; measured number above the stated range.
By their numbers in this assay, from the lowest: compound 2; then compounds 1 and 3 (each within the scatter of the next).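

Moving the chlorine within the chlorophenyl group is not a neutral change at this position: in this assay, 4-chlorophenyl in place of 3-chlorophenyl gives an 11-fold higher number from compound 2 to compound 3 (1.02 log units; beyond the scatter), although the two groups have the same atoms. Going by these compounds alone, the earlier compounds kept the chlorine in one place, so only this pair shows that its placement matters. Nothing measured here explains the step.

As far as these compounds go, it remains open whether a methoxy group or an amine in place of the chlorine would retain the number of compound 2. From the compounds shown here alone, whether the step would recur without the fluoro also remains open.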